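A Sulfopropyl Chain in Place of the Hydroxyazetidine

This account rests on a few compounds, and the source may have more. Where it says the series, first, only, none or still open, it means among the compounds named here.

Measured compounds in an assay on isolated protein for displacement of a labelled ligand from 5-hydroxytryptamine receptor 6 (Homo sapiens); a higher number here means a weaker inhibitor, a lower number a stronger inhibitor:
compound 1, `NC[C@@H]1CCCc2cc(S(=O)(=O)c3cccc(F)c3)ccc21`, gives 0.0794 nM
compound 2, `CN(C)S(=O)(=O)NC[C@@H]1CCCc2cc(S(=O)(=O)c3cccc(F)c3)ccc21`, gives 2 nM
compound 3, `O=S(=O)(c1cccc(F)c1)c1ccc2c(c1)CCC[C@H]2CN1CC(O)C1`, gives 0.1 nM

Compound 3 stands second highest of the three numbers; its nearest neighbour is compound 1, and the two lie within the scatter, while compound 2 sits far above it, as the step of a 20-fold lower number from compound 2 to compound 3 (1.30 log units; beyond the scatter) shows. The new compound 4, `O=S(=O)(O)CCCNC[C@@H]1CCCc2cc(S(=O)(=O)c3cccc(F)c3)ccc21`, differs from compound 3 by (3-sulfopropyl)amino in place of 3-hydroxyazetidin-1-yl on a saturated chain carbon bound to a saturated ring carbon.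

Among the measured compounds shown here, two measured steps bear on this change. The step of a 1.3-fold higher number from compound 1 to compound 3 (0.10 log units; within the scatter) shows that closing the amine into the hydroxyazetidine ring changed little. The step of a 25-fold higher number from compound 1 to compound 2 (1.40 log units; beyond the scatter) shows that attaching a sulfur-bearing group directly to the amine nitrogen cost a great deal. In compound 4 the sulfur sits at the end of a three-carbon chain rather than on the nitrogen itself, and the nitrogen keeps a hydrogen, so neither step settles the case. A moderate loss is expected, a 10-fold higher number from compound 3 to compound 4 (1.00 log units; beyond the scatter). For compound 4 the expected value in this assay is 1 nM, with a range from 0.2 nM to 8 nM.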

Compound 4, inhibition constant: 1.26 nM
The estimate for compound 4 lay 1.3-fold (0.10 log units) below the measured number; the range from low to high includes it.
By their numbers in this assay, from the lowest: compounds 1 and 3 (each within the scatter of the next); then compounds 4 and 2 (each within the scatter of the next).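

Putting 3-sulfopropyl on the amine nitrogen gives a 16-fold higher number from compound 1 to compound 4 (1.20 log units; beyond the scatter) in this assay, and the swap for 3-hydroxyazetidin-1-yl gives a 13-fold higher number from compound 3 to compound 4 (1.10 log units; beyond the scatter), so this position accepts the hydroxyazetidine with no step beyond the scatter but not the sulfopropyl chain. Against the dimethylsulfamoyl group, the result is a 1.6-fold lower number from compound 2 to compound 4 (0.20 log units; within the scatter), so these two sulfur-bearing groups cannot be told apart here, whether the sulfur sits on the nitrogen or at the end of a chain. Nothing available gives a cause for these steps.

As far as these compounds go, it remains open whether the large steps follow from the sulfo group or from the chain that carries it. A plain propyl chain, a chain ending in a carboxylic acid, or a chain ending in a hydroxyl on the same nitrogen would help separate the two.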